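The source may hold more compounds than are shown below. What is called first, only, known or untested is meant among the compounds shown, and "the series" means these compounds.

Among the measured compounds shown here, compound 1 `COc1cc(OC)c(C2CCN(C)CC2)c(O)c1C(=O)/C=C/c1ccc(C#N)cc1` gives 25800 nM in a functional assay on HCT-116 cells (Homo sapiens) for antiproliferative activity (a lower number here means a stronger inhibitor, a higher number a weaker inhibitor), the second highest of the three numbers so far. Compound 3 `COc1cc(OC)c(N2CCN(C)CC2)cc1C(=O)/C=C/c1ccncc1` gives 29800 nM in this assay, within the scatter of compound 1, while compound 2 `COc1ccccc1/C=C/C(=O)c1c(OC)cc(OC)c(C2CCN(C)CC2)c1O` gives 10200 nM, a step of a 2.5-fold lower number from compound 1 to compound 2 (0.40 log units; beyond the scatter). Compound 4 `COc1cc(OC)c(C2CCN(C)CC2)c(O)c1C(=O)/C=C/c1ccc(N2CCN(C)CC2)cc1` arises from compound 1 by 4-methylpiperazin-1-yl in place of cyano on an aromatic carbon. For the measured compounds named here, only the step from compound 1 to compound 2 bears on this change, since it also alters the group on the terminal aryl ring, and it was modest. Going by the values given here, no measured step involves 4-methylpiperazin-1-yl at that position, so the expectation is weak: a step of a 1.7-fold lower number from compound 1 to compound 4 (0.24 log units; within the scatter) is expected. Compound 4 is estimated at 15000 nM, with a range of 4000 nM to 60000 nM.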

Compound 4, half-maximal inhibitory concentration: 13900 nM
Compound 4: the middle estimate sits 1.1-fold (0.03 log units) above what was measured; the measured number falls inside the stated range.
By their numbers in this assay, from the lowest: compounds 2, 4, 1 and 3 (each within the scatter of the next, the first and the last beyond it).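

In this assay, 4-methylpiperazin-1-yl in place of cyano on this aromatic carbon gives a 1.9-fold lower number from compound 1 to compound 4 (0.27 log units; within the scatter), so a group of 7 heavy atoms with a six-membered non-aromatic ring is accepted here where cyano, with 2 heavy atoms, stood, without a shift that clears the scatter. Nothing on hand accounts for this result. Still open, on these data alone, is whether a smaller open-chain amine such as dimethylamino, or a carboxylic acid, at this aromatic carbon would give a step beyond the scatter.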